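This account rests on a few compounds, and the source may have more. Where it says the series, first, only, none or still open, it means among the compounds named here.

Going by the values given here, in a functional assay on KB cells (Homo sapiens) for antiproliferative activity, read by sulforhodamine B assay, with a stated time of 3 days (a lower number here means a stronger inhibitor of growth, a higher number a weaker inhibitor of growth), two compounds with the same core have numbers so far. Compound 1 (`O=C(Nc1cccc(Nc2ncc(F)c(Nc3ccc(F)cc3)n2)c1)c1cnccn1`) gives 23600 nM and compound 2 (`CN1CCC(C(=O)Nc2cccc(Nc3ncc(F)c(Nc4ccc(F)cc4)n3)c2)CC1`) gives 1700 nM as the lower of the two numbers, so compound 2 is the stronger inhibitor of growth in this pair. Compound 3 (`CN(C)c1ccc(C(=O)Nc2cccc(Nc3ncc(F)c(Nc4ccc(F)cc4)n3)c2)cc1`) carries 4-(dimethylamino)phenyl in place of 1-methylpiperidin-4-yl on a carbonyl carbon, a change counted as 4-(dimethylamino)phenyl in place of 1-methylpiperidin-4-yl on a carbonyl carbon that leaves the rest of the structure as it is. Among the compounds with values here, only one measured step bears on this: a 14-fold lower number from compound 1 to compound 2 (1.14 log units; beyond the scatter) is a large one, made when 1-methylpiperidin-4-yl replaced pyrazin-2-yl at that same carbonyl carbon. Within the data shown here, compound 3 gives up that group and again has an aromatic ring there, but no measured compound carries 4-(dimethylamino)phenyl, so the guide is thin. A partial return towards the higher number is therefore expected, smaller than the measured step. The estimate is a 3.5-fold higher number from compound 2 to compound 3 (0.55 log units; beyond the scatter) in this assay as a moderate rise. For compound 3 the expected value is 6000 nM with 1800 nM to 20000 nM as the estimated range.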

Compound 3, concentration for 50% growth inhibition: > 10000 nM
Compound 3 gave a limit, no number; the forecaster's own chance of this, stated with the estimate: 5%; middle value at least 1.6-fold (0.22 log units) from the limit.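

Compound 3 stands at a limit, not a number, in this assay: the limit of > 10000 nM in this assay, at which 1 of the 3 values shown sits. Even so, putting 4-(dimethylamino)phenyl on the carbonyl carbon in place of 1-methylpiperidin-4-yl gives an at least 5.8-fold higher number from compound 2 to compound 3 (0.76 log units; beyond the scatter), so the gain seen earlier, a 14-fold lower number from compound 1 to compound 2 (1.14 log units; beyond the scatter), is not kept with this aromatic ring, and among the three groups shown at this carbonyl carbon only 1-methylpiperidin-4-yl gives a number clearly lower than the others. The step between the pyrazin-2-yl and 4-(dimethylamino)phenyl compounds cannot be read, so these two aromatic rings cannot be ranked against each other.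

The compounds shown leave open whether the lower number of compound 2 goes with the non-aromatic ring itself or with its methyl-bearing ring nitrogen: a piperidin-4-yl without the methyl, a cyclohexyl ring without the nitrogen, or an open dimethylaminoethyl chain on the same carbonyl carbon would separate the two. They also leave open whether a morpholine ring, with its oxygen, would behave like 1-methylpiperidin-4-yl at this carbonyl carbon.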